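The source may hold more compounds than are shown below. What is called first, only, known or untested is meant among the compounds shown, and "the series" means these compounds.

Compound 1, `COc1ccc(-c2cccc(C(=O)N(C)C)c2)cc1S(=O)(=O)Nc1cccc(NCCNC(=O)c2ccccc2)c1`: in an assay on CHO-K1 cells for agonist activity at Orexin receptor type 2 (Homo sapiens), read by a luciferase reporter (a higher number here means that more compound is needed for the effect, a lower number that less compound is needed), compound 1 gives > 10000 nM, which is a limit of the assay and not a number.
Compound 2, `COc1ccc(C(=O)NCCNc2cccc(NS(=O)(=O)c3cc(-c4cccc(C(=O)N(C)C)c4)ccc3OC)c2)cc1`: compound 2 gives 1050 nM.
Compound 3, `COc1ccc(-c2cccc(C(=O)N(C)C)c2)cc1S(=O)(=O)Nc1cccc(NCCNC(=O)c2ccccc2C)c1`: compound 3 gives 800 nM.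

The three compounds share one core and differ only in the ring attached to the carbonyl at the chain end. Compound 3 has the lowest of the two numbers, but its nearest neighbour compound 2 is within the scatter (a 1.3-fold lower number from compound 2 to compound 3 (0.12 log units; within the scatter)), so the two cannot be ordered. Compound 1 sits at the limit of > 10000 nM in this assay, at which 1 of the 3 values shown sits. Both steps away from compound 1 were clear: an at least 9.5-fold lower number from compound 1 to compound 2 (0.97 log units; beyond the scatter) and an at least 12-fold lower number from compound 1 to compound 3 (1.09 log units; beyond the scatter).

Compound 4, `COc1ccc(-c2cccc(C(=O)N(C)C)c2)cc1S(=O)(=O)Nc1cccc(NCCNC(=O)c2cccc(Cl)c2)c1`, has not been measured. Its change from compound 3 is 3-chlorophenyl in place of 2-methylphenyl on a carbonyl carbon. Within the data shown here, neither measured step tests a chlorine or this position, so the only guide is that a substituted ring gave a number where the plain ring gave a limit. Compound 4 is therefore expected to stay near compound 3, with a step of a 1.5-fold higher number from compound 3 to compound 4 (0.18 log units; within the scatter), and its expected value is 1200 nM, within 400 nM to 5000 nM.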

Compound 4, half-maximal effective concentration: 94 nM
Compound 4: the middle estimate sits 13-fold (1.11 log units) above what was measured; measured number outside the range, below it.
By their numbers in this assay, from the lowest: compound 4; then compounds 3 and 2 (each within the scatter of the next). At a limit, above all of these: compound 1.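

In this assay, the 2-methylphenyl and 4-methoxyphenyl compounds could not be ordered, yet 3-chlorophenyl on this carbonyl carbon stands apart from both: an 8.5-fold lower number from compound 3 to compound 4 (0.93 log units; beyond the scatter) and an 11-fold lower number from compound 2 to compound 4 (1.05 log units; beyond the scatter). So which group the ring carries matters here, not only whether it carries one, and against the plain ring the chloro group gives an at least 100-fold lower number from compound 1 to compound 4 (2.02 log units; beyond the scatter). That step is only a minimum, as compound 1 stands at a limit and not at a number: the limit of > 10000 nM in this assay, at which 1 of the 4 values shown sits.

On these data alone, whether the drop belongs to the chlorine itself or to where it sits stays open, and a 3-methylphenyl or 4-chlorophenyl ring would separate the two. Also open, as far as these compounds go, is whether a ring carrying an amine or a carboxylic acid, or a longer chain in place of the present one, would keep a number this low.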